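This account rests on a few compounds, and the source may have more. Where it says the series, first, only, none or still open, it means among the compounds named here.

Measured so far in a functional assay on PC-3 cells (Homo sapiens) for antiproliferative activity, read by MTT assay, with a stated time of 24 h; a higher number here means a weaker inhibitor, a lower number a stronger inhibitor:
Compound 1, `CCn1c(C(=O)N[C@@H](C)C(=O)OC)ccc1C(CC)(CC)c1ccc(OCS(=O)(=O)c2ccccc2)c(C)c1`: > 50000 nM, a limit of the assay rather than a number.
Compound 2, `CCn1c(C(=O)N[C@@H](CC(=O)OC)C(=O)OC)ccc1C(CC)(CC)c1ccc(OCS(=O)(=O)c2ccccc2)c(C)c1`: 6490 nM.
Compound 3, `CCn1c(C(=O)N[C@@H](CO)C(C)C)ccc1C(CC)(CC)c1ccc(OCS(=O)(=O)c2ccccc2)c(C)c1`: 10600 nM.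

Compound 3 gives the highest of the two numbers shown, but the step of a 1.6-fold higher number from compound 2 to compound 3 (0.21 log units; within the scatter) is within the scatter, so compound 2 and compound 3 are not set apart. Compound 1 stands only at a limit, (the limit of > 50000 nM in this assay, at which 1 of the 3 values shown sits).

Compound 4, `CCn1c(C(=O)N[C@@H](CC(=O)O)C(=O)O)ccc1C(CC)(CC)c1ccc(OCS(=O)(=O)c2ccccc2)c(C)c1`, is not yet measured. It differs from compound 3 in one place: 1,2-dicarboxyethyl in place of 1-(hydroxymethyl)-2-methylpropyl on an amide-type nitrogen. Compound 2 carries 1,2-bis(methoxycarbonyl)ethyl on the same amide-type nitrogen, the methyl ester counterpart of the group entering in compound 4.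

Among the compounds with values here, two measured steps bear on the change. The step of an at least 7.7-fold lower number from compound 1 to compound 2 (0.88 log units; beyond the scatter) shows that a methoxycarbonyl added to the chain gave a lower number, beyond the scatter. The step of a 1.6-fold higher number from compound 2 to compound 3 (0.21 log units; within the scatter) shows that exchanging the groups on the amide-type nitrogen gave no difference beyond the scatter. Within the data shown here, no measured step tests a free carboxylic acid, so the direction for compound 4 is open, and no step beyond the scatter is expected.

Compound 4 is therefore estimated at 15000 nM, with a range from 5000 nM to 50000 nM. The expected step is a 1.4-fold higher number from compound 3 to compound 4 (0.15 log units; within the scatter).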

Compound 4, half-maximal inhibitory concentration: > 50000 nM
Compound 4 gave a limit, no number; the forecaster's own chance of this, stated with the estimate: 30%; middle value at least 3.3-fold (0.52 log units) from the limit.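

In this assay compound 4 gives > 50000 nM, a limit of the assay and not a number. On the amide-type nitrogen, 1,2-bis(methoxycarbonyl)ethyl and 1-(hydroxymethyl)-2-methylpropyl could not be set apart, whereas 1,2-dicarboxyethyl is set apart from both, with an at least 7.7-fold higher number from compound 2 to compound 4 (0.88 log units; beyond the scatter) and an at least 4.7-fold higher number from compound 3 to compound 4 (0.67 log units; beyond the scatter), so the free diacid is clearly less favourable here than its methyl ester counterpart. The step between compound 1 and compound 4 cannot be read, so 1-(methoxycarbonyl)ethyl and 1,2-dicarboxyethyl remain unseparated, and the series now has two compounds without a number: the limit of > 50000 nM in this assay, at which 2 of the 4 values shown sit.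

From the compounds shown here alone, it remains open whether a single carboxylic acid is enough to produce this loss, as a group carrying one carboxylic acid and one methyl ester on the same chain would show. Also open, going by these compounds, is whether the second methoxycarbonyl of compound 2 can be exchanged for a primary carboxamide or extended to a longer chain, as in 1,3-bis(methoxycarbonyl)propyl, while the number stays clear of the assay limit.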